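Adding One Fluoro to the Benzyl Group of Compound 3

This account rests on a few compounds, and the source may have more. Where it says the series, first, only, none or still open, it means among the compounds named here.

Of the compounds shown here, three sharing a core have been measured in an ADME assay on C8166 cells (Homo sapiens) for cytotoxicity, read by MTT assay; a lower number here means that less compound is tolerated, a higher number that more compound is tolerated. Compound 1 `Cc1ccc(-n2cc(C(=O)O)c(=O)c3c(O)c(Cc4cccc(Cl)c4F)ccc32)cc1` gives 194000 nM and compound 2 `O=C(O)c1cn(-c2ccc(Br)cc2)c2ccc(Cc3cccc(Cl)c3F)c(O)c2c1=O` gives 85000 nM, while compound 3 `O=C(O)c1cn(Cc2ccccc2)c2ccc(Cc3cccc(Cl)c3F)c(O)c2c1=O` gives 20300 nM as the lowest number of the three.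

Compound 4 `O=C(O)c1cn(Cc2ccccc2F)c2ccc(Cc3cccc(Cl)c3F)c(O)c2c1=O` differs from compound 3 in one place, with fluoro in place of hydrogen on an aromatic carbon, ortho to a large group (fluoro in place of hydrogen on an aromatic carbon). This turns benzyl into 2-fluorobenzyl.

Going by the values given here, no measured step makes this exact change. The closest is a 2.3-fold lower number from compound 1 to compound 2 (0.36 log units; beyond the scatter) for bromo in place of methyl on an aromatic carbon. The larger steps, a 9.6-fold lower number from compound 1 to compound 3 (0.98 log units; beyond the scatter) and a 4.2-fold lower number from compound 2 to compound 3 (0.62 log units; beyond the scatter), each exchange the whole group on the aromatic nitrogen, so they bear on this change only loosely.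

A single added fluoro is therefore expected to give little movement, with no step beyond the scatter in this assay and no favoured direction. The expected result is a 1.0-fold lower number from compound 3 to compound 4 (0.01 log units; within the scatter) on this estimate.

Compound 4 is estimated at 20000 nM (expected range 9000 nM to 45000 nM).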

Compound 4, half-maximal cytotoxic concentration: 44900 nM
Compound 4: middle estimate off by 2.2-fold (0.35 log units), on the low side, within the range that was stated.
By their numbers in this assay, from the lowest: compound 3; then compounds 4 and 2 (each within the scatter of the next); then compound 1.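

In this assay the single fluoro that turns benzyl into 2-fluorobenzyl gives a 2.2-fold higher number from compound 3 to compound 4 (0.34 log units; beyond the scatter) and so has a modest but real effect at this place on the ring, ortho to a large group, with more compound tolerated after the change. The gap to the aryl compounds also narrows: a 1.9-fold lower number from compound 2 to compound 4 (0.28 log units; within the scatter) lies within the scatter, so these two cannot be told apart, whereas a 4.3-fold lower number from compound 1 to compound 4 (0.64 log units; beyond the scatter) still leaves a clear difference. Nothing available explains why this one atom shifts the number.

On these data alone, it remains open whether chloro, methyl or methoxy at the same place would shift the number as fluoro does. As far as these compounds go, it is also open whether fluoro elsewhere on the benzyl ring would do the same.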